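The source may report more compounds than this note shows. Statements on the series, on what has been measured and on what is new or still open speak of the compounds shown alone.

This account follows the step from compound 2 to compound 3 in an ADME assay on BJ cells (Homo sapiens) for cytotoxicity, read by CellTiter-Glo and resazurin assay, with a stated time of 72 h; on this read-out higher numbers stand for an effect only at larger amounts of compound and lower numbers for an effect already at smaller amounts. Compound 1 `CC(C)N(Cc1cccc(OCCCCCC(=O)O)c1)C(=O)c1ccc(-c2cccc(Oc3ccccc3)c2)cc1` reaches only a limit in this assay, given as > 18700 nM. Compound 2 `CCOC(=O)CCCCCOc1cccc(CN(C(=O)c2ccc(-c3cnc(OC)nc3OC)cc2)C(C)C)c1` likewise gives only a limit in this assay, > 26000 nM. For the measured compounds named here, neither of these values is a number, so compound 2 stands at a limit, and the one further value shown is a limit as well; no step between measured compounds can be stated, and nothing in the two values sets one compound apart from the other. Compound 3 `CCOC(=O)CCCCCOc1cccc(CN(C(=O)c2ccc(-c3cccc(O)c3)cc2)C(C)C)c1` is not yet measured. It differs from compound 2 in one place: 3-hydroxyphenyl in place of 2,4-dimethoxypyrimidin-5-yl on an aromatic carbon. With both measured compounds sitting at limits, the expected step is a step that the limit leaves unreadable from compound 2 to compound 3, which amounts to nothing beyond the usual scatter. Compound 3 is most likely to return a limit again. Compound 3 is estimated at 30000 nM in this assay, with a range from 10000 nM to 90000 nM.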

Compound 3, half-maximal effective concentration: > 26000 nM
Compound 3 gave a limit, no number (the forecaster's own chance of this, stated with the estimate: 75%); the middle value lies beyond the limit too.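

No step from compound 2 to compound 3 can be read in this assay, since neither compound gives a number, only a limit: the limit of > 26000 nM in this assay, at which 2 of the 3 values shown sit.

The compounds shown leave open whether 3-hydroxyphenyl and 2,4-dimethoxypyrimidin-5-yl differ at all in this read-out beyond that limit.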